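The compounds below may be only part of what the source reports. "The series", "measured", "known", "first", "only" and "open" are said of these compounds alone.

Values so far in an ADME assay on Vero cells (Chlorocebus sabaeus) for cytotoxicity, read by MTT assay, with a stated time of 72 h; a higher number here means that more compound is tolerated, a lower number that less compound is tolerated
Compound 1 `CCOC(=O)c1c(-c2ccc(OC)cc2)oc2ccc(OCCCCCN3C(=O)C(=O)c4cc(F)ccc43)cc12` at 512 ug/mL
Compound 2 `CCOC(=O)c1c(-c2ccc(OC)cc2)oc2ccc(OCCCCCCN3C(=O)/C(=N\OC)c4cc(F)ccc43)cc12` at 16 ug/mL
Compound 3 `CCOC(=O)c1c(-c2ccc(OC)cc2)oc2ccc(OCCCCCCN3C(=O)/C(=N\OC)c4ccccc43)cc12` at 32 ug/mL

Compound 2 and compound 3 sit within the scatter of each other at the low end of these numbers, while compound 1 reads far higher. Compound 4 `CCOC(=O)c1c(-c2ccc(F)cc2)oc2ccc(OCCCCCCN3C(=O)/C(=N\OC)c4cc(F)ccc43)cc12` departs from compound 2 by fluoro in place of methoxy on an aromatic carbon as fluoro in place of methoxy on an aromatic carbon, 4-methoxyphenyl to 4-fluorophenyl. Among the compounds with values here, the only measured step of a 2.0-fold higher number from compound 2 to compound 3 (0.30 log units; within the scatter) is a different change, hydrogen in place of fluoro, and lies within the scatter. Within the data shown here, no measured step covers this exchange, so the expectation stays near compound 2 at 16 ug/mL in this assay with no shift beyond the scatter. The expected size is a 1.3-fold higher number from compound 2 to compound 4 (0.10 log units; within the scatter) and so within the scatter. Compound 4 is estimated at 20 ug/mL (expected range 8 ug/mL to 64 ug/mL) in this read-out.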

Compound 4, half-maximal cytotoxic concentration: 16 ug/mL
Compound 4: the middle estimate sits 1.3-fold (0.10 log units) above what was measured; low and high end bracket the measured number.
By their numbers in this assay, from the lowest: compounds 2, 4 and 3 (each within the scatter of the next); then compound 1.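

In this assay, the exchange of 4-methoxyphenyl for 4-fluorophenyl gives no change at the digits printed from compound 2 to compound 4 (within the scatter), so on this aromatic carbon, para to a large group, fluoro in place of methoxy leaves the reading within the scatter. The earlier single-place step covered only hydrogen in place of fluoro at a different place in the molecule. No evidence accompanies this result.

Going by these compounds, whether an amine or a carboxylic acid at this aromatic carbon would also stay within the scatter remains open. So does the reading of a longer chain on the shared core.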